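Ethoxy to dimethylamino: cytotoxicity notes on the series

The source may report more compounds than this note shows. Statements on the series, on what has been measured and on what is new or still open speak of the compounds shown alone.

Values in an ADME assay on cells (Homo sapiens) for cytotoxicity, read by polymerase chain reaction, with a stated time of 3 days (on this read-out lower numbers stand for higher toxicity in this test and higher numbers for lower toxicity in this test), for the measured compounds:
- compound 1 `Nc1nc(Cl)c(-c2nc3ccccc3s2)c(N[C@@H]2C[C@H](CO)[C@@H](O)[C@H]2O)n1`: 14000 nM
- compound 2 `Nc1nc(Cl)c(-c2nc3ccc(F)cc3s2)c(N[C@@H]2C[C@H](CO)[C@@H](O)[C@H]2O)n1`: > 25000 nM (a limit of the assay)
- compound 3 `CCOc1ccc2nc(-c3c(Cl)nc(N)nc3N[C@@H]3C[C@H](CO)[C@@H](O)[C@H]3O)sc2c1`: > 25000 nM (a limit of the assay)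

Compound 3 has no number in this assay, only a limit. Its value sits at the limit of > 25000 nM in this assay, at which 2 of the 3 values shown sit, so it can only be said that compound 3 is no more toxic than the limit allows. The measured steps that touch compound 3 are an at least 1.7-fold higher number from compound 1 to compound 3 (0.25 log units; that floor lies within the scatter) and, from the other side, a step that the two limits leave unreadable from compound 2 to compound 3; the related step of an at least 1.7-fold higher number from compound 1 to compound 2 (0.25 log units; that floor lies within the scatter) also ends at a limit. For the measured compounds named here, no measured step here changes one substituent for another on a numbered value, so nothing sets a size for the change to compound 4 `CN(C)c1ccc2nc(-c3c(Cl)nc(N)nc3N[C@@H]3C[C@H](CO)[C@@H](O)[C@H]3O)sc2c1`.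

The change is dimethylamino in place of ethoxy on an aromatic carbon. Since compound 3 is itself at the limit, the expectation in this assay for compound 4 is a step of no readable size, most likely another limit: the estimated step is a number no higher from compound 3 to compound 4 (the limit leaves the size open). The estimate for compound 4 is 25000 nM, with a range from 10000 nM to 60000 nM, and a limit rather than a number is expected more often than not.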

Compound 4, half-maximal cytotoxic concentration: > 25000 nM
Compound 4: a limit, no number; the forecaster's own chance of this, stated with the estimate: 60%; the middle value sits exactly at the limit.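

In this assay compound 4 gives > 25000 nM, a limit of the assay and not a number, so dimethylamino on this aromatic carbon gives no more sign of toxicity in this test than ethoxy or fluoro did. Against hydrogen at this position, the one readable step is an at least 1.7-fold higher number from compound 1 to compound 4 (0.25 log units; that floor lies within the scatter), while the steps linking compound 4 to the ethoxy and fluoro compounds cannot be read. With dimethylamino, a third substituent at this position now ends at the same limit, and swapping the oxygen of ethoxy for the nitrogen of dimethylamino brings no readable change: the limit of > 25000 nM in this assay, at which 3 of the 4 values shown sit.

As far as these compounds go, the true values of compound 2, compound 3 and compound 4 remain unknown, so their order and any real separation from compound 1 remain open. Also open, from the compounds shown here alone, is whether another group at this position, such as a carboxylic acid, a nitrile or a longer alkoxy chain, would give a number within the range of the assay rather than another limit.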